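The source may report more compounds than this note shows. Statements on the series, on what has been measured and on what is new or still open speak of the compounds shown alone.

Three compounds have numbers in a physicochemical assay for solubility, read by HPLC, in phosphate buffer, measured as kinetic solubility, at pH 7.4; on this read-out higher numbers stand for higher solubility and lower numbers for lower solubility: compound 1 (`CCC(=O)c1cc(C)n(-c2ccc(S(N)(=O)=O)cc2)c1-c1ccc(Cl)cc1`) gives 6900 nM, compound 2 (`CCCc1cc(-c2ccccc2)n(-c2ccc(S(N)(=O)=O)cc2)c1C`) gives 3800 nM and compound 3 (`NS(=O)(=O)c1ccc(-c2cc(C(=O)CC3CCC3)nn2-c2ccc(Cl)cc2)cc1`) gives 4300 nM. Compound 3 stands within the scatter of both others, so these numbers show no separation. Compound 4 (`NS(=O)(=O)c1ccc(-c2cc(C(=O)NN3CCCCC3)nn2-c2ccc(Cl)cc2)cc1`) has (piperidin-1-yl)amino in place of cyclobutylmethyl on a carbonyl carbon. Among the measured compounds shown here, no measured pair differing in one place is available, so nothing sizes this change, and no direction can be assigned in this assay. The expected step, a 1.1-fold lower number from compound 3 to compound 4 (0.03 log units; within the scatter), stays inside the scatter. Compound 4 is estimated at 4000 nM, with an expected range of 1500 nM to 10000 nM.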

Compound 4, solubility: 53700 nM
Estimate against measurement, compound 4: 13-fold (1.13 log units) below; the whole stated range lies below it.
By their numbers in this assay, from the lowest: compounds 2, 3 and 1 (each within the scatter of the next); then compound 4.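

In this assay, among the compounds shown here, this site on the carbonyl carbon is the first to show a step beyond the scatter: (piperidin-1-yl)amino in place of cyclobutylmethyl gives a 12-fold higher number from compound 3 to compound 4 (1.10 log units; beyond the scatter). The entering group brings a hydrogen-bond donor and acceptor, which the leaving group lacks, but no measurement here shows what drives the step.

Which part of the entering group carries the step remains open. A cyclohexylamino group or a directly attached piperidin-1-yl on the same carbonyl carbon would separate the contributions of the two nitrogens.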